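Removing One Hydroxy From a Dihydroxyphenyl Urea

The source may hold more compounds than are shown below. What is called first, only, known or untested is meant among the compounds shown, and "the series" means these compounds.

Compound 3 `CN(C)CCn1cnnc1-c1cc(Oc2ccc(NC(=O)N/N=C/c3ccc(O)c(O)c3)cc2F)ccn1` stands second highest of the three numbers in a functional assay on NCI-H460 cells (Homo sapiens) for cytotoxicity, read by MTT assay, with a stated time of 72 h (on this read-out higher numbers stand for weaker inhibition and lower numbers for stronger inhibition), with 1930 nM. Compound 1 `CN(C)CCn1cnnc1-c1cc(Oc2ccc(NC(=O)N/N=C/c3cccc(O)c3)cc2F)ccn1` gives 780 nM, and compound 2 `CN(C)CCn1cnnc1-c1cc(Oc2ccc(NC(=O)N/N=C/c3ccc(O)c(F)c3)cc2F)ccn1` gives 2620 nM. Compound 4 `CN(C)CCn1cnnc1-c1cc(Oc2ccc(NC(=O)N/N=C/c3ccc(O)cc3)cc2F)ccn1` differs from compound 3 by hydrogen in place of hydroxy on an aromatic carbon. The step that bears most on this is a 2.5-fold higher number from compound 1 to compound 3 (0.39 log units; beyond the scatter), the same kind of change run the other way, where hydroxy entered in place of hydrogen; the step of a 1.4-fold lower number from compound 2 to compound 3 (0.13 log units; within the scatter), where hydroxy replaced fluoro, stayed within the scatter. With hydroxy leaving compound 3, a modest move toward a lower number is expected, a 1.6-fold lower number from compound 3 to compound 4 (0.21 log units; within the scatter). Compound 4 is thus estimated at 1200 nM, with a range from 500 nM to 3000 nM.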

Compound 4, half-maximal inhibitory concentration: 1780 nM
For compound 4 the middle estimate is 1.5-fold (0.17 log units) below the measured one; measured number inside the range.
By their numbers in this assay, from the lowest: compound 1; then compounds 4, 3 and 2 (each within the scatter of the next).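

In this assay, hydrogen, hydroxy and fluoro at this place on the ring read alike: removing the hydroxy stays within the scatter (a 1.1-fold lower number from compound 3 to compound 4 (0.04 log units; within the scatter)), as does hydrogen in place of fluoro (a 1.5-fold lower number from compound 2 to compound 4 (0.17 log units; within the scatter)). The clearer difference comes with the 4-hydroxyphenyl in place of the 3-hydroxyphenyl (a 2.3-fold higher number from compound 1 to compound 4 (0.36 log units; beyond the scatter)). No measurement at hand explains that difference. The compounds shown leave open whether a methoxy or an amine at this place would read alike too, and whether an amine could stand in for the hydroxy of compound 1.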